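From 4-bromophenyl to 2,3-dichlorophenyl on the shared core

A few compounds are considered here, and "the series" means these few. Any claim that something is new, unique, unknown or untested is made for them only; others in the source may bear on it.

- compound 1 `NC1=NC2(CCSCC2)N(OCCCOc2cccc(Cl)c2)C(N)=N1` gives 130 nM in a functional assay on MDA-MB-231 cells (Homo sapiens) for antiproliferative activity, read by MTT assay, with a stated time of 72 h; on this read-out higher numbers stand for weaker inhibition and lower numbers for stronger inhibition
- compound 2 `NC1=NC2(CCSCC2)N(OCCCOc2ccc(Br)cc2)C(N)=N1` gives 440 nM in this assay

Compound 2 holds the higher of these two numbers and so shows the weaker inhibition. Going by the values given here, the one measured step is a 3.4-fold higher number from compound 1 to compound 2 (0.53 log units; beyond the scatter) and it is modest but beyond the scatter, with 4-bromophenyl in place of 3-chlorophenyl. Compound 3 `NC1=NC2(CCSCC2)N(OCCCOc2cccc(Cl)c2Cl)C(N)=N1` has not yet been measured. It carries 2,3-dichlorophenyl in place of 4-bromophenyl on an oxygen on a saturated carbon on the shared core. Among the compounds with values here, compound 3 thus lacks the 4-bromophenyl, as compound 1 does, but no measured compound carries 2,3-dichlorophenyl. A lower number in this assay is therefore expected, by somewhat less than that one step. The expected change is a 2.3-fold lower number from compound 2 to compound 3 (0.36 log units; beyond the scatter) on this estimate. For compound 3 the estimated value is 190 nM with an expected range from 60 nM to 550 nM in this assay.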

Compound 3, half-maximal inhibitory concentration: 1 nM
Compound 3: middle estimate off by 190-fold (2.28 log units), on the high side, and the stated range ends above it.
By their numbers in this assay, from the lowest: compound 3; then compound 1; then compound 2.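

In this assay, the aryl group on this oxygen proves able to move the number much further than the earlier pair showed: a 440-fold lower number from compound 2 to compound 3 (2.64 log units; beyond the scatter), against a 3.4-fold higher number from compound 1 to compound 2 (0.53 log units; beyond the scatter). Most of that reach comes from one small change, chloro in place of hydrogen on an aromatic carbon, which turns 3-chlorophenyl into 2,3-dichlorophenyl and gives a 130-fold lower number from compound 1 to compound 3 (2.11 log units; beyond the scatter). Nothing available here accounts for the size of this step.

The compounds shown leave open whether 2-chlorophenyl alone would give a similar number or whether both chloro groups are needed. They also leave open whether 2,3-difluorophenyl or 2,3-dimethylphenyl would match 2,3-dichlorophenyl, and whether the low number of compound 3 would survive a longer chain on the oxygen.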